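Urea isomer step on a shared thieno core

A few compounds are considered here, and "the series" means these few. Any claim that something is new, unique, unknown or untested is made for them only; others in the source may bear on it.

Two ureas share one core. Compound 1 `O=C(Nc1cccc(C(F)(F)F)c1)Nc1nnc(Sc2ncnc3scc(-c4ccncc4)c23)s1` carries a 3-(trifluoromethyl)phenyl on an amide-type nitrogen, and in a functional assay on HepG2 cells (Homo sapiens) for antiproliferative activity, read by MTT assay, with a stated time of 48 h (a lower number here means a stronger inhibitor, a higher number a weaker inhibitor), compound 1 gives 15300 nM. Compound 2 `O=C(Nc1ccc(F)cc1)Nc1nnc(Sc2ncnc3scc(-c4ccncc4)c23)s1` carries a 4-fluorophenyl at the same place; in this assay compound 2 gives 31700 nM, the highest of the two numbers, the step being a 2.1-fold higher number from compound 1 to compound 2 (0.32 log units; beyond the scatter). Compound 3 `O=C(Nc1cccc(F)c1)Nc1nnc(Sc2ncnc3scc(-c4ccncc4)c23)s1` is unmeasured; it differs from compound 2 by 3-fluorophenyl in place of 4-fluorophenyl on an amide-type nitrogen. Going by the values given here, the only measured step that bears on this change is a 2.1-fold higher number from compound 1 to compound 2 (0.32 log units; beyond the scatter), which swapped a 3-substituted phenyl for a 4-substituted one, but with a different substituent, so it is an imperfect guide. On that single step a modest move towards a lower number, or none beyond the scatter, is expected for compound 3 in this assay, that is a 1.6-fold lower number from compound 2 to compound 3 (0.20 log units; within the scatter). Compound 3 is therefore estimated at 20000 nM, with a range from 8000 nM to 50000 nM.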

Compound 3, half-maximal inhibitory concentration: 64100 nM
Compound 3: middle estimate off by 3.2-fold (0.51 log units), on the low side; measured number outside the range, above it.
By their numbers in this assay, from the lowest: compound 1; then compound 2; then compound 3.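

Moving the fluorine on the phenyl is not a neutral change in this assay: 3-fluorophenyl in place of 4-fluorophenyl on the amide-type nitrogen gives a 2.0-fold higher number from compound 2 to compound 3 (0.31 log units; beyond the scatter) even though the two compounds have the same atoms. Among the 3-substituted phenyls, fluoro in place of trifluoromethyl on an aromatic carbon gives a 4.2-fold higher number from compound 1 to compound 3 (0.62 log units; beyond the scatter), the largest step in the set. The substituent's identity therefore counts as well as its placement, since compound 1 and compound 3 share a placement yet hold the lowest and highest numbers of the three. No measurement at hand gives a reason for either step. Still open, going by these compounds, is how 4-(trifluoromethyl)phenyl would compare with compound 1, and whether an amine or a carboxylic acid on the phenyl would lower the number.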